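The source may hold more compounds than are shown below. What is called first, only, known or untested is meant among the compounds shown, and "the series" means these compounds.

In a functional assay on HepG2 cells (Homo sapiens) for antiproliferative activity, read by MTT assay, with a stated time of 48 h (a higher number here means a weaker inhibitor, a lower number a stronger inhibitor), compound 1 `COc1ccc(N(C)c2ccnc(Cl)n2)cc1F` gives 844 nM and compound 2 `COc1ccc(N(C)c2cc(C)nc(C)n2)cc1` gives 824 nM, while compound 3 `COc1ccc(N(C)c2cc(C)nc(C)n2)cc1F` gives 2060 nM as the highest number of the three, which makes it the weakest inhibitor so far. Compound 4 `COc1ccc(N(C)c2cc(C)nc(C)n2)cc1Cl` differs from compound 3 by a single exchange (chloro in place of fluoro on an aromatic carbon): chloro in place of fluoro on an aromatic carbon, ortho to a methoxy group. For the measured compounds named here, the only measured step at this carbon is a 2.5-fold higher number from compound 2 to compound 3 (0.40 log units; beyond the scatter) for fluoro in place of hydrogen, a modest change. Going by the values given here, no measured pair compares chloro with fluoro, so that step offers a sense of scale but no direction. In this assay only a small move is therefore expected, perhaps toward a lower number, and none clearly beyond the scatter. The expected step is a 1.4-fold lower number from compound 3 to compound 4 (0.14 log units; within the scatter) and remains an estimate only. For compound 4 the estimated value is 1500 nM within an expected range from 550 nM to 4000 nM in this assay.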

Compound 4, half-maximal inhibitory concentration: 787 nM
Estimate against measurement, compound 4: 1.9-fold (0.28 log units) above; the measured number falls inside the stated range.
By their numbers in this assay, from the lowest: compounds 4, 2 and 1 (each within the scatter of the next); then compound 3.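

In this assay, the aromatic carbon ortho to a methoxy group now proves sensitive to which halogen it carries: a 2.6-fold lower number from compound 3 to compound 4 (0.42 log units; beyond the scatter), opposite in direction to a 2.5-fold higher number from compound 2 to compound 3 (0.40 log units; beyond the scatter). Hydrogen and chloro at this carbon cannot be told apart, with a 1.0-fold lower number from compound 2 to compound 4 (0.02 log units; within the scatter), so in this series of three compounds only fluoro stands apart, and the change from hydrogen does not follow a single direction across the two halogens. Nothing available explains why fluoro differs from both hydrogen and chloro here.

From the compounds shown here alone, it remains open whether a bromo, a methyl or a nitrile at this carbon would group with fluoro or with hydrogen and chloro. Going by these compounds, it is also open whether the gap between fluoro and chloro would persist with the other substitution on the core seen in compound 1.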